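Fluorine on the side chain of compound 3

The compounds below may be only part of what the source reports. "The series", "measured", "known", "first", "only" and "open" are said of these compounds alone.

In a functional assay on HL-60 cells (Homo sapiens) for cytotoxicity, read by WST assay, with a stated time of 48 h (on this read-out lower numbers stand for stronger inhibition and higher numbers for weaker inhibition), compound 1 `COc1cc(C(c2ccc(O)c(OC)c2)[C@H](C)C(C)C)ccc1O` gives 17000 nM and compound 3 `CC[C@H](C(C)C)C(c1ccc(O)c(OC)c1)c1ccc(O)c(OC)c1` gives 16000 nM and these two stand level within the scatter. Compound 2 `COc1cc(C(c2ccc(O)c(OC)c2)[C@H](C)[C@H](C)CO)ccc1O` reads > 100000 nM as a limit of the assay. The step of an at least 6.2-fold lower number from compound 2 to compound 3 (0.79 log units; beyond the scatter) lies beyond the scatter. Compound 4 `COc1cc(C(c2ccc(O)c(OC)c2)[C@H](C)[C@H](C)CF)ccc1O` follows from 2-(fluoromethyl)-1-methylpropyl in place of 1-isopropylpropyl on a saturated chain carbon bound to two aromatic carbons with 2-(fluoromethyl)-1-methylpropyl in place of 1-isopropylpropyl on a saturated chain carbon bound to two aromatic carbons. Compound 4 carries fluorine rather than the hydroxy of compound 2, so its expected size follows a 1.1-fold lower number from compound 1 to compound 3 (0.03 log units; within the scatter) rather than an at least 5.8-fold higher number from compound 1 to compound 2 (0.76 log units; beyond the scatter) in this series. The expected step of a 1.6-fold higher number from compound 3 to compound 4 (0.19 log units; within the scatter) is none beyond the scatter. In this assay compound 4 is estimated at 25000 nM with a range from 9000 nM to 70000 nM as expected.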

Compound 4, half-maximal inhibitory concentration: 56000 nM
The estimate for compound 4 lay 2.2-fold (0.35 log units) below the measured number; low and high end bracket the measured number.
By their numbers in this assay, from the lowest: compounds 3 and 1 (each within the scatter of the next); then compound 4. At a limit, above all of these: compound 2.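

In this assay, fluoro in place of hydrogen on the chain does change the number, with a 3.3-fold higher number from compound 1 to compound 4 (0.52 log units; beyond the scatter), whereas the added methyl left it level, with a 1.1-fold lower number from compound 1 to compound 3 (0.03 log units; within the scatter). The 2-(fluoromethyl)-1-methylpropyl group, which counts no hydrogen-bond donor, also separates from 1-isopropylpropyl, with a 3.5-fold higher number from compound 3 to compound 4 (0.54 log units; beyond the scatter), so the loss at this chain end is not confined to the hydroxy of compound 2. Compound 2 stands at a limit, so an at least 1.7-fold lower number from compound 2 to compound 4 (0.25 log units; that floor lies within the scatter) is a floor and not a size: the limit of > 100000 nM in this assay, at which 1 of the 4 values shown sits.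

From the compounds shown here alone, whether an amine or a methoxy at this chain end would read like compound 4 stays open.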